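The compounds below may be only part of what the source reports. "The series", "measured", "known", "first", "only" and "open" are said of these compounds alone.

Of the compounds shown here, three have been measured in an ADME assay on HEL cells (Homo sapiens) for cytotoxicity, with a stated time of 3 days; on this read-out lower numbers stand for higher toxicity in this test and higher numbers for lower toxicity in this test. Compound 1 `CCC1(Cc2ccccc2)OS(=O)(=O)C=C1OS(=O)(=O)c1ccc(C)cc1` gives 400000 nM. Compound 3 `CCC1(Cc2ccccc2)OS(=O)(=O)C=C1OC(c1ccccc1)c1ccccc1` returns only a limit of the test, >= 80000 nM, and no number. Compound 2 `CCC1(Cc2ccccc2)OS(=O)(=O)C=C1OCc1ccccc1Cl` likewise stands at a limit, >= 20000 nM, which is not a number; among the three values shown, one further value is also a limit (the limit of >= 20000 nM in this assay, at which 1 of the 3 values shown sits, and (the limit of >= 80000 nM in this assay, at which 1 of the 3 values shown sits)), so compound 2 cannot be ranked against the others. The unmeasured compound 4 `CCC1(Cc2ccccc2)OS(=O)(=O)C=C1OCCCc1ccccc1` differs from compound 2 in one place: phenethyl in place of 2-chlorophenyl on a saturated chain carbon bound to an oxygen on an unsaturated carbon. Among the measured compounds shown here, no step between two measured compounds that differ in one place is available in this set, so there is no precedent to lean on. The change keeps one six-membered aromatic ring of carbon only and alters neither hydrogen-bond donors nor acceptors. The step that the limit leaves unreadable from compound 2 to compound 4 is expected to lie within the scatter, with a fair chance that compound 4 also returns only a limit. Compound 4 is therefore expected to give 60000 nM, within a range from 20000 nM to 400000 nM.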

Compound 4, minimum cytotoxic concentration: >= 20000 nM
Compound 4: a limit, no number (the forecaster's own chance of this, stated with the estimate: 60%); the middle value does not contradict the limit.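

Among the compounds shown here, compound 2 and compound 4 both return only a limit in this assay and no step between them can be read. The compounds shown leave open whether phenethyl in place of 2-chlorophenyl on a saturated chain carbon bound to an oxygen on an unsaturated carbon changes the minimum cytotoxic concentration at all.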